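Nitro Substitution on the Anilide Ring: Cytotoxicity Notes

This account rests on a few compounds, and the source may have more. Where it says the series, first, only, none or still open, it means among the compounds named here.

Two members of the series have numbers in an ADME assay on MT4 cells (Homo sapiens) for cytotoxicity, read by MTT assay; on this read-out higher numbers stand for lower toxicity in this test and lower numbers for higher toxicity in this test. Compound 1 `COC(=O)c1ccc(NC(=O)CSc2nncnc2-c2cccc3ccccc23)c(Br)c1` gives 173000 nM in this assay. Compound 2 `O=C(CSc1nncnc1-c1ccccc1Cl)Nc1ccccc1` gives 127000 nM in this assay, the lower of the two numbers; the gap to compound 1 is within the scatter, so the two compounds cannot be told apart on this read-out, and no pattern can be drawn from two values this close. Both sit at the weakly toxic end of the range covered by this assay.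

Compound 3 `O=C(CSc1nncnc1-c1ccccc1Cl)Nc1ccccc1[N+](=O)[O-]` has not yet been run in this assay. It differs from compound 2 in one place: nitro in place of hydrogen on an aromatic carbon. Among the measured compounds shown here, no pair of measured compounds with a single difference is available, so nothing itself shows what this change does to the read-out. With the two measured values lying within the scatter of each other, the step from compound 2 to compound 3 is expected to be small, a 1.1-fold lower number from compound 2 to compound 3 (0.02 log units; within the scatter), not beyond the scatter in either direction. Compound 3 is therefore estimated at 120000 nM in this assay, with a range from 50000 nM to 300000 nM.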

Compound 3, half-maximal cytotoxic concentration: 63000 nM
The estimate for compound 3 lay 1.9-fold (0.28 log units) above the measured number; low and high end bracket the measured number.
By their numbers in this assay, from the lowest: compounds 3, 2 and 1 (each within the scatter of the next, the first and the last beyond it).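

Among the compounds shown here, compound 2 and compound 3 form the first pair that differs in one place, and so give the first direct reading of phenyl to 2-nitrophenyl in this assay: a 2.0-fold lower number from compound 2 to compound 3 (0.30 log units; within the scatter). Placing nitro on this aromatic carbon, ortho to a large group, therefore gives a step that stays within the scatter, so this single pair shows no change in cytotoxicity that can be told apart from repeat variation, though a larger step could not have been excluded before this result. No measurement available here bears on the reason for this outcome.

One pair speaks for one group at one place on the ring, so the reading cannot be extended to other substituents or other positions. On these data alone, an amine, a carboxylic acid or a methoxy group at this same place remains open, as does nitro on another carbon of this ring, and so does whether the same change would read alike on the core of compound 1.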